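The compounds below may be only part of what the source reports. "The series", "measured", "known", "first", "only" and "open" are said of these compounds alone.

Values in an ADME assay on microsomes from liver (Homo sapiens) for pharmacokinetics, using NADPH, with a stated time of 30 min, tested at 1 uM (on this read-out lower numbers stand for slow clearance and higher numbers for fast clearance), follow
compound 1 (`C[C@H](Nc1ncnc(N)c1C#N)c1nc2ccc(F)cc2c(-c2ccccn2)c1-c1ccccn1`): 47 mL.min-1.g-1
compound 2 (`C[C@H](Nc1ncnc(N)c1C#N)c1nc2ccc(F)cc2c(C(=O)N(C)C)c1-c1ccccc1`): 198 mL.min-1.g-1

Compound 1 holds the lower of the two numbers, and compound 2 stands higher, beyond the scatter. Compound 3 (`CCNC(=O)c1c(-c2ccccn2)c([C@H](C)Nc2ncnc(N)c2C#N)nc2ccc(F)cc12`) has not yet been measured. It keeps the core of compound 1 but carries ethylcarbamoyl in place of pyridin-2-yl on an aromatic carbon, opposite the ring nitrogen (ethylcarbamoyl in place of pyridin-2-yl on an aromatic carbon). Going by the values given here, no measured pair shows this change alone, so any forecast in this assay rests on thin evidence. Among the compounds with values here, compound 2 (198 mL.min-1.g-1) is the only measured compound with a carbonyl group, which points weakly to a rise rather than a fall. The expected step, upward and close to the scatter in size, is a 2.0-fold higher number from compound 1 to compound 3 (0.31 log units; beyond the scatter) as estimated here. Compound 3 is expected at 95 mL.min-1.g-1 (estimated range 40 mL.min-1.g-1 to 220 mL.min-1.g-1).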

Compound 3, intrinsic clearance in microsomes: < 14 mL.min-1.g-1
Compound 3: a limit, no number; the forecaster's own chance of this, stated with the estimate: 5%; middle value at least 6.7-fold (0.83 log units) away from the limit.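

In this assay, going by these compounds alone, ethylcarbamoyl in place of pyridin-2-yl on the aromatic carbon opposite the ring nitrogen gives an at least 3.3-fold lower number from compound 1 to compound 3 (0.52 log units; beyond the scatter), the only single-place step so far. Compound 3 gives < 14 mL.min-1.g-1, which is a limit of the assay and not a number. Pyridin-2-yl is therefore not required at this position for slow clearance, and the full size of the step remains unknown: the limit of < 14 mL.min-1.g-1 in this assay, at which 1 of the 3 values shown sits.

This single pair cannot separate the contributions of the amide hydrogen, the ethyl chain and the loss of the aromatic ring. Going by these compounds, what a carboxylic acid, an amine or a longer chain on this carbon would give in this assay also remains open.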